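This account rests on a few compounds, and the source may have more. Where it says the series, first, only, none or still open, it means among the compounds named here.

Two members of the series have been measured in an assay on isolated protein for inhibition of Amine oxidase [flavin-containing] A (Homo sapiens), read by fluorescence, with stated times of 15 min and 20 min; on this read-out lower numbers stand for stronger inhibition and higher numbers for weaker inhibition. Compound 1, `CC(C)(C)c1cc(/C=C/C(=O)NC2CCN(Cc3ccccc3)CC2)cc(C(C)(C)C)c1O`, gives 42500 nM in this assay. Compound 2, `CC(C)(C)c1cc(/C=C/C(=O)NCCC2CCN(Cc3ccccc3)CC2)cc(C(C)(C)C)c1O`, gives 62300 nM in this assay. Of these two numbers compound 2 sits at one end, but its gap to compound 1 lies within the usual scatter of repeated measurements, so the two compounds cannot be told apart on these data. Compound 3, `CC(C)(C)c1cc(/C=C/C(=O)NCCC2CCN(Cc3ccc(F)c(F)c3)CC2)cc(C(C)(C)C)c1O`, has not yet been measured. Its structural difference from compound 2 is 3,4-difluorophenyl in place of phenyl on a saturated chain carbon bound to an amine nitrogen in a ring; the same difference, cut one bond further out, reads benzyl to 3,4-difluorobenzyl. Within the data shown here, no measured pair shows this change, so the data give no step to lean on. The expectation for this assay is a step no larger than the scatter in either direction, a 1.1-fold lower number from compound 2 to compound 3 (0.05 log units; within the scatter). Compound 3 is therefore estimated at 55000 nM in this assay, with a range from 20000 nM to 150000 nM.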

Compound 3, half-maximal inhibitory concentration: 64500 nM
Compound 3: middle estimate off by 1.2-fold (0.07 log units), on the low side; low and high end bracket the measured number.
By their numbers in this assay, from the lowest: compounds 1, 2 and 3 (each within the scatter of the next).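

In this assay, 3,4-difluorophenyl in place of phenyl on a saturated chain carbon bound to an amine nitrogen in a ring gives a 1.0-fold higher number from compound 2 to compound 3 (0.02 log units; within the scatter), so the two compounds cannot be told apart. Among these compounds, this is the first step read at this position, and it shows that this change, which takes the group from 6 to 8 heavy atoms, does not separate compound 3 from compound 2 on this read-out. No available measurement bears on the reason for this result.

Going by these compounds, it remains open whether a different group at this place, such as a pyridyl ring or a methoxyphenyl group, would separate from compound 2 in this assay. On these data alone, it also remains open whether the 3,4-difluorobenzyl group would give a similar result on the core of compound 1.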